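A few compounds are considered here, and "the series" means these few. Any claim that something is new, unique, unknown or untested is made for them only; others in the source may bear on it.

Working notes on the series. The shared core carries a propylsulfanyl group and a benzyl group, and the hydrazone arm is varied. Compound 1 `CCCSc1nc(N/N=C/c2ccc(C)cc2)c2nnn(Cc3ccccc3)c2n1` is read in a functional assay on ECa-109 cells (Homo sapiens) for antiproliferative activity, read by MTT assay, with a stated time of 72 h; a lower number here means a stronger inhibitor, a higher number a weaker inhibitor. In this assay compound 1 gives only a limit, > 64000 nM. Compound 2 `CCCSc1nc(N/N=C/c2cccs2)c2nnn(Cc3ccccc3)c2n1` likewise gives only a limit in this assay, > 64000 nM. Compound 3 `CCCSc1nc(N/N=C/c2ccc(Br)cc2)c2nnn(Cc3ccccc3)c2n1` also gives only a limit in this assay, > 64000 nM. The steps a step that the two limits leave unreadable from compound 1 to compound 2, a step that the two limits leave unreadable from compound 1 to compound 3 and a step that the two limits leave unreadable from compound 2 to compound 3 therefore stay unreadable, since (the limit of > 64000 nM in this assay, at which 3 of the 3 values shown sit). Compound 4 `CCCSc1nc(N/N=C/c2c(O)ccc3ccccc23)c2nnn(Cc3ccccc3)c2n1` differs from compound 3 by 2-hydroxynaphthalen-1-yl in place of 4-bromophenyl on a carbon with a double bond to nitrogen. For the measured compounds named here, no measured step bears on a hydroxynaphthyl arm, so the expectation rests only on the three limits. For compound 4 the expected value in this assay is 40000 nM, ranging from 4000 nM to 150000 nM. The expected step is an at least 1.6-fold lower number from compound 3 to compound 4 (0.20 log units; that floor lies within the scatter), most likely again ending at the limit.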

Compound 4, half-maximal inhibitory concentration: 9290 nM
Compound 4: middle estimate off by 4.3-fold (0.63 log units), on the high side; measured number inside the range.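

Among the arms shown, only 2-hydroxynaphthalen-1-yl gives a readable number in this assay, with an at least 6.8-fold lower number from compound 3 to compound 4 (0.83 log units; beyond the scatter), an at least 6.8-fold lower number from compound 2 to compound 4 (0.83 log units; beyond the scatter) and an at least 6.8-fold lower number from compound 1 to compound 4 (0.83 log units; beyond the scatter). These steps are floors rather than sizes, because the other three arms each give only a limit: the limit of > 64000 nM in this assay, at which 3 of the 4 values shown sit.

The compounds shown do not separate the hydroxyl group from the second aromatic ring, and they leave open how a plain naphthalen-1-yl arm or a 2-hydroxyphenyl arm would read. From the compounds shown here alone, the effect of an amine in place of the propylsulfanyl group also stays open.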